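A few compounds are considered here, and "the series" means these few. Any claim that something is new, unique, unknown or untested is made for them only; others in the source may bear on it.

In a physicochemical assay for lipophilicity, measured as octanol-water partition (on this read-out lower numbers stand for lower lipophilicity and higher numbers for higher lipophilicity), compound 3 `CC(C)[C@@H]1CC[C@@H](C)C[C@H]1OC(=O)c1ccccc1` gives 4.82 and stands in the middle: compound 2 `CCC(=O)O[C@@H]1C[C@H](C)CC[C@H]1C(C)C` reads 3.54 at the low end and compound 1 `CC(C)[C@@H]1CC[C@@H](C)C[C@H]1OC(=O)c1cccc(Cl)c1` reads 5.34 at the high end. Compound 4 `Cc1cccc(C(=O)O[C@@H]2C[C@H](C)CC[C@H]2C(C)C)c1` carries methyl in place of hydrogen on an aromatic carbon compared with compound 3. The closest guide is the step of a number 0.52 log units lower from compound 1 to compound 3 (beyond the scatter) where hydrogen replaces chloro on an aromatic carbon. Read in reverse, this modest step shows a substituent on that ring going with a higher number. The step of a number 1.28 log units higher from compound 2 to compound 3 (beyond the scatter) is large but concerns phenyl in place of ethyl on a carbonyl carbon, elsewhere in the molecule, so it bears little here. A modest rise is therefore expected, with a number 0.48 log units higher from compound 3 to compound 4 (beyond the scatter) as the estimated step. Compound 4 is estimated at 5.3 (expected range 5 to 5.6).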

Compound 4, partition coefficient: 5.29
The estimate for compound 4 lay 0.01 log units above the measured number; the range from low to high includes it.
By their numbers in this assay, from the lowest: compound 2; then compound 3; then compounds 4 and 1 (each within the scatter of the next).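

Methyl on the aromatic carbon meta to a large group has its own step in this assay, a number 0.47 log units higher from compound 3 to compound 4 (beyond the scatter), so chloro is not the only group there that goes with a higher number than hydrogen. The two groups cannot be told apart at this place, with a number 0.05 log units lower from compound 1 to compound 4 (within the scatter). Nothing available explains either step. The compounds shown leave open how an amine or a carboxylic acid on that same carbon would read, and whether a longer chain there would follow methyl.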